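This account rests on a few compounds, and the source may have more. Where it says the series, first, only, none or still open, it means among the compounds named here.

Compound 1, `Fc1ccc(Nc2nc(-c3cccc(F)c3)nc3ccc(F)cc23)cc1`: in a functional assay on HT29-AK cells (Homo sapiens) for cytotoxicity, read by MTT assay, with a stated time of 48 h (on this read-out lower numbers stand for stronger inhibition and higher numbers for weaker inhibition), compound 1 gives > 50000 nM, a limit of the assay.
Compound 2, `Fc1cccc(Nc2nc(-c3cccc(F)c3)nc3ccc(F)cc23)c1`: in this assay compound 2 gives > 50000 nM, a limit of the assay.
Compound 3, `Fc1cccc(-c2nc(Nc3ccccc3F)c3cc(F)ccc3n2)c1`: in this assay compound 3 gives > 50000 nM, a limit of the assay.

Compound 3 thus stands at the same limit as the other two fluorophenyl compounds. The three steps among them, a step that the two limits leave unreadable from compound 1 to compound 2, a step that the two limits leave unreadable from compound 1 to compound 3 and a step that the two limits leave unreadable from compound 2 to compound 3, cannot be read, and the limit of > 50000 nM in this assay, at which 3 of the 3 values shown sit, is all that is known of the set. Compound 4, `Fc1cccc(-c2nc(Nc3ccc(Cl)cc3)c3cc(F)ccc3n2)c1`, differs from compound 3 in one place: 4-chlorophenyl in place of 2-fluorophenyl on a nitrogen on an aromatic ring. Among the compounds with values here, no measured step bears directly on a chlorine in place of a fluorine on this phenyl ring; the steps among the fluorophenyl isomers show only that every placing of the fluorine left the compound at the limit. Nothing here points to a gain beyond the scatter, so compound 4 is expected to remain near the limit as well. The step from compound 3 is estimated as a step that the limit leaves unreadable from compound 3 to compound 4. Compound 4 is estimated at 60000 nM in this assay, with a likely range from 15000 nM to 200000 nM, and a real chance that only a limit is reported again.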

Compound 4, half-maximal inhibitory concentration: 40300 nM
Compound 4: middle estimate off by 1.5-fold (0.17 log units), on the high side, and the stated range covers the measured number.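

In this assay, within the data shown here, compound 4 gives 40300 nM, the only value shown that is a reading and not a limit, so a 4-chlorophenyl on this nitrogen brings the set within the range the assay can read. Set against the fluorophenyl compounds, the change reads as an at least 1.2-fold lower number from compound 3 to compound 4 (0.09 log units; that floor lies within the scatter), as an at least 1.2-fold lower number from compound 2 to compound 4 (0.09 log units; that floor lies within the scatter) and, for chloro in place of fluoro on an aromatic carbon, as an at least 1.2-fold lower number from compound 1 to compound 4 (0.09 log units; that floor lies within the scatter); each of these is only a floor, so the true size of the steps stays unknown. What this adds is therefore one reading and no demonstrated strong gain, and the set as a whole remains at the edge of the assay: the limit of > 50000 nM in this assay, at which 3 of the 4 values shown sit.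

The compounds shown leave open how a 4-bromophenyl or a 4-methoxyphenyl would read on this nitrogen, and whether a 2-chlorophenyl or a 3-chlorophenyl would also give a number and not a limit. They also leave open whether a carboxylic acid or an amine in place of the fluoro on the shared core would move the number well clear of the limit.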